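Side-chain amine exchange on the shared core

The compounds below may be only part of what the source reports. "The series", "measured", "known", "first", "only" and "open" are said of these compounds alone.

Measured in a functional assay on C32 cells (Homo sapiens) for antiproliferative activity, read by WST assay, with a stated time of 72 h; a higher number here means a weaker inhibitor, a lower number a stronger inhibitor:
- compound 1 `CCN(CC)CC#CCSc1nc2c(c(=O)[nH]c(=O)n2C)n1C` gives 26400 nM
- compound 2 `Cn1cnc2nc(SCC#CCN3CCCCC3)nc(SCC#CCN3CCCCC3)c21` gives 6390 nM
- compound 3 `Cn1c(SCC#CCN2CCCC2)nc2c1c(=O)[nH]c(=O)n2C` gives 51100 nM

Compound 3 and compound 1 form the upper pair of these three numbers and lie within the scatter of each other. Compound 2 stands lower, at 6390 nM, against 51100 nM for compound 3.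

The next change leads to compound 4 `Cn1c(SCC#CCN2CCCCC2)nc2c1c(=O)[nH]c(=O)n2C`: piperidin-1-yl in place of pyrrolidin-1-yl on a saturated chain carbon bound to a triple-bonded carbon. In words, piperidin-1-yl comes in place of pyrrolidin-1-yl on a saturated chain carbon bound to a triple-bonded carbon.

Among the measured compounds shown here, only one measured step bears directly on this place: a 1.9-fold higher number from compound 1 to compound 3 (0.29 log units; within the scatter). There, pyrrolidin-1-yl replaced diethylamino, and the number moved no further than the scatter. For the measured compounds named here, compound 2 also carries piperidin-1-yl, but its core differs from that of compound 3, so the pair gives no clean step. With so little evidence, no shift beyond the scatter is expected in this assay, and any lean in direction is weak, towards a slightly lower number.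

The expected step is a 1.3-fold lower number from compound 3 to compound 4 (0.13 log units; within the scatter). For compound 4 the estimated value is 38000 nM, with an expected range of 16000 nM to 85000 nM.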

Compound 4, half-maximal inhibitory concentration: 355000 nM
Estimate against measurement, compound 4: 9.3-fold (0.97 log units) below; the measured number lies above the stated range.
By their numbers in this assay, from the lowest: compound 2; then compounds 1 and 3 (each within the scatter of the next); then compound 4.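

Working notes on the amine position: in this assay, the place on a saturated chain carbon bound to a triple-bonded carbon proves sensitive to the amine after all, since piperidin-1-yl in place of pyrrolidin-1-yl gives a 6.9-fold higher number from compound 3 to compound 4 (0.84 log units; beyond the scatter) on the shared core. Measured against diethylamino, the same ring gives a 13-fold higher number from compound 1 to compound 4 (1.13 log units; beyond the scatter) and so stands apart from the earlier exchange, which gave a 1.9-fold higher number from compound 1 to compound 3 (0.29 log units; within the scatter) and stayed within the scatter. The data at hand offer no explanation for this separation of piperidin-1-yl from the other two amines.

Still open, on these data alone, is where a morpholin-4-yl ring, an azepan-1-yl ring or a dimethylamino group would fall at this place, and thus whether the rise follows the six-membered ring itself or something specific to piperidin-1-yl. Compound 2 also carries piperidin-1-yl but differs from compound 4 in more than one place, so it cannot show whether the same exchange would have a comparable effect on a different core.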